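The source may report more compounds than this note shows. Statements on the series, on what has been measured and on what is new or still open speak of the compounds shown alone.

Compound 3 `CC(O)(CSc1ccccc1)c1nc(-c2ccc([N+](=O)[O-])c(C(F)(F)F)c2)no1` and compound 1 `CC(O)(CSc1ccc(Br)cc1)c1nc(-c2ccc([N+](=O)[O-])c(C(F)(F)F)c2)no1` share one core and differ in a single place: bromo in place of hydrogen on an aromatic carbon. In a functional assay on DU-145 cells (Homo sapiens) for cytotoxicity, read by MTT assay (on this read-out higher numbers stand for weaker inhibition and lower numbers for stronger inhibition), compound 3 gives 3000 nM, while compound 1 gives 1600 nM, so the change produced a 1.9-fold lower number from compound 3 to compound 1 (0.27 log units; within the scatter). Compound 2 `CC(O)(CS(=O)(=O)c1ccccc1)c1nc(-c2ccc(F)c(Cl)c2)no1` is built on another core, and the difference between the two cores is not broken down here. In this assay compound 2 reaches only a limit of the assay, > 100000 nM. Compound 4 `CC(O)(CS(=O)(=O)c1ccc(Br)cc1)c1nc(-c2ccc(F)c(Cl)c2)no1` has not yet been measured; it differs from compound 2 by bromo in place of hydrogen on an aromatic carbon, the same change as that made from compound 3 to compound 1, at the same place. In this assay compound 4 is expected to give about 150000 nM. That estimate means a step that the limit leaves unreadable from compound 2 to compound 4, and it rests on compound 2 sitting at the limit of > 100000 nM in this assay, at which 1 of the 3 values shown sits, together with the earlier step, a 1.9-fold lower number from compound 3 to compound 1 (0.27 log units; within the scatter).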

Compound 4, half-maximal inhibitory concentration: 75000 nM
Compound 4: middle estimate off by 2.0-fold (0.30 log units), on the high side, within the range that was stated.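

On the core of compound 2, the change gives an at least 1.3-fold lower number from compound 2 to compound 4 (0.12 log units; that floor lies within the scatter) in this assay. Compound 2 stands at a limit of the assay, > 100000 nM, so this step is a floor and not a measured size: the limit of > 100000 nM in this assay, at which 1 of the 4 values shown sits. The two cores show nothing against the change carrying over, but they do not establish that it does, as the earlier step and this floor both lie within the scatter: the same change on two cores in this assay, a 1.9-fold lower number (0.27 log units; within the scatter) from compound 3 to compound 1 and an at least 1.3-fold lower number (0.12 log units; that floor lies within the scatter) from compound 2 to compound 4; the limit leaves it open whether they differ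

The compounds shown leave open whether a chloro group, a methoxy group or an amine in place of the bromo would give a similar result. They also leave open how the change would behave on two cores that differ from each other in one place only.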